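Shared core series: 2,3-difluorophenyl to 1H-pyrazol-4-yl exchange

The compounds below may be only part of what the source reports. "The series", "measured", "known", "first", "only" and "open" are said of these compounds alone.

Of the compounds shown here, two of the shared core have been measured so far. Compound 1 `CC(C)(C)Cc1c(-c2cccc(F)c2F)sc(N)c1C(=O)c1ccc(Cl)cc1` gives 1% in an assay on CHO cells for displacement of a labelled ligand from adenosine receptor A3 (Homo sapiens), read by scintillation counting, tested at 10 uM; a lower number here means less inhibition, a higher number more inhibition at the concentration tested (going by the name of the read-out). Compound 2 `CC(C)(C)Cc1c(Br)sc(N)c1C(=O)c1cccc(C(F)(F)F)c1` gives 4% in this assay. The two readings lie within the scatter of each other, so compound 1 stands together with compound 2 near the bottom of the inhibition scale, with no separation between them. For the measured compounds named here, no step between measured compounds that differ in a single place is available, so no measured single-change step can be drawn on here.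

Compound 3 `CC(C)(C)Cc1c(-c2cn[nH]c2)sc(N)c1C(=O)c1ccc(Cl)cc1` has not yet been measured in this assay. It differs from compound 1 by 1H-pyrazol-4-yl in place of 2,3-difluorophenyl on an aromatic carbon. With both measured compounds reading close to zero inhibition, the expected step is a number 4 percentage points higher from compound 1 to compound 3 (within the scatter), none beyond the scatter in this assay. Compound 3 is estimated at 5% in this assay, with a range from -5% to 20%. Wider movement cannot be ruled out, since no measured compound of the series carries the entering group.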

Compound 3, a percentage reported as inhibition, at one concentration (the size of the read-out at that concentration, not a potency): 1%
Estimate against measurement, compound 3: 4 percentage points above; the range from low to high includes it.
By their numbers in this assay, from the lowest: compounds 1, 3 and 2 (each within the scatter of the next).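

In this assay, for the compounds shown here, the exchange of 2,3-difluorophenyl for 1H-pyrazol-4-yl gives no change at the digits printed from compound 1 to compound 3 (within the scatter) and this is the first measured single-change step. At this aromatic carbon next to the ring sulfur, a six-membered aromatic ring of carbon only with 0 hydrogen-bond donors and a five-membered aromatic ring with 2 hetero atoms and 1 hydrogen-bond donor thus give readings within the scatter of each other, both close to zero inhibition, so the entering ring brings no measurable inhibition at the concentration tested, and any further fall could not be seen from readings this low. No measured information bears on why the reading stays where it is.

Open, on these data alone, is whether any group on this carbon lifts the reading clear of the scatter, for instance an aminomethyl group, a carboxylic acid or a longer chain such as n-hexyl. Also open, as far as these compounds go, is whether 1H-pyrazol-4-yl would read differently with a cyclohexylmethyl group in place of the neopentyl group, since a core reading this low says little about what the ring can do elsewhere.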